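Swapping phenyl for 3-amino-4-methylphenyl on the ring nitrogen

The compounds below may be only part of what the source reports. "The series", "measured", "known", "first", "only" and "open" are said of these compounds alone.

Three compounds share one core and differ only on a ring nitrogen: compound 1 `COc1ccc([C@H]2CC(=O)N(Cc3cccc(C#N)c3)C2)cc1OC1CCCC1` with 3-cyanobenzyl, compound 2 `COc1ccc([C@H]2CC(=O)N(C(C)=O)C2)cc1OC1CCCC1` with acetyl and compound 3 `COc1ccc([C@H]2CC(=O)N(c3ccccc3)C2)cc1OC1CCCC1` with phenyl. In a functional assay on HEK293 cells (Homo sapiens) for cytotoxicity (on this read-out higher numbers stand for lower toxicity in this test and lower numbers for higher toxicity in this test), compound 1 gives > 10000 nM as a limit. In this assay compound 2 gives > 10000 nM as a limit too. In this assay compound 3 gives > 10000 nM as a limit, so it has no number of its own. Among the compounds with values here, all the data so far stand at the limit of > 10000 nM in this assay, at which 3 of the 3 values shown sit, and no compound is separated from the others.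

Compound 4 `COc1ccc([C@H]2CC(=O)N(c3ccc(C)c(N)c3)C2)cc1OC1CCCC1` carries 3-amino-4-methylphenyl in place of phenyl on an amide-type nitrogen in a ring, a change counted as 3-amino-4-methylphenyl in place of phenyl on an amide-type nitrogen in a ring in full. Within the data shown here, three measured steps bear on it, all on that same nitrogen. They are a step that the two limits leave unreadable from compound 1 to compound 2 along with a step that the two limits leave unreadable from compound 1 to compound 3 along with a step that the two limits leave unreadable from compound 2 to compound 3 and none offers a size to carry over.

The expectation therefore rests on compound 3 at > 10000 nM as a limit. No clear direction is expected, and the estimated step is a step that the limit leaves unreadable from compound 3 to compound 4 at most a loose guess. For compound 4 the estimated value is 15000 nM with an expected range from 4000 nM to 50000 nM in this read-out.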

Compound 4, half-maximal cytotoxic concentration: > 10000 nM
Compound 4 gave a limit, no number (the forecaster's own chance of this, stated with the estimate: 75%); the middle value does not contradict the limit.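

In this assay, within the data shown here, compound 4 gives > 10000 nM, a limit and not a number, so no step from compound 1, compound 2 or compound 3 to compound 4 can be read. Whether any of these groups on the amide-type nitrogen separates one compound from another stays open, with all four compounds at one value: the limit of > 10000 nM in this assay, at which 4 of the 4 values shown sit.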